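Replacing the guanidine side chain with sec-butyl in compound 2

The source may hold more compounds than are shown below. What is called first, only, known or untested is meant among the compounds shown, and "the series" means these compounds.

Measured compounds:
- compound 1, `O=C(CN(c1nc(Cl)nc2[nH]cnc12)C1CC1)N[C@@H](CO)C(=O)OCc1ccccc1`: 34.5%
- compound 2, `N=C(N)NCCC[C@H](NC(=O)CN(c1nc(Cl)nc2[nH]cnc12)C1CC1)C(=O)O`: 17%
- compound 3, `O=C(CN(c1ncnc2c1ncn2C1CCCCO1)C1CC1)N[C@@H](CCC(=O)OCc1ccccc1)C(=O)OCc1ccccc1`: 20.7%

In a functional assay on the whole organism (Tail, strain ICR) with Mus musculus as the target, in the tail flick test, with a stated time of 120 min, at a dose of 25 umol/kg by the oral route (on this read-out lower numbers stand for a weaker effect and higher numbers for a stronger effect at the one dose given), compound 2 gives 17%, the lowest of the three numbers. Its nearest neighbour is compound 3, whose value is within the scatter of that of compound 2, while compound 1 lies beyond the scatter above it. Compound 4, `CC[C@H](C)[C@H](NC(=O)CN(c1nc(Cl)nc2[nH]cnc12)C1CC1)C(=O)O`, has not yet been measured in this assay. It differs from compound 2 in one place: a group of 4 heavy atoms (4 carbon; no ring) in place of a group of 7 heavy atoms (4 carbon, 3 nitrogen; no ring), on a saturated chain carbon bound to an amide-type nitrogen and a carbonyl carbon. The free carboxylic acid and the shared core of compound 2 are kept.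

For the measured compounds named here, no step between measured compounds carries this change, so the expectation rests on compound 2 alone. Because compound 2 gives 17% and the acid is unchanged, the step from compound 2 to compound 4 in this assay is expected to be small, a number 5 percentage points higher from compound 2 to compound 4 (within the scatter), in no direction that clearly exceeds the scatter. Compound 4 is therefore estimated at 22% in this assay, within a range from 8% to 40%.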

Compound 4, a percentage reported as activity, at one dose (the size of the read-out at that dose, not a potency): 21.4%
The estimate for compound 4 lay 0.6 percentage points above the measured number, within the range that was stated.
By their numbers in this assay, from the lowest: compounds 2, 3 and 4 (each within the scatter of the next); then compound 1.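

For the compounds shown here, exchanging the group of 7 heavy atoms for sec-butyl, on a saturated chain carbon bound to an amide-type nitrogen and a carbonyl carbon, gives in this assay a number 4.4 percentage points higher from compound 2 to compound 4 (within the scatter), the only step in this set that isolates a single change. With the free carboxylic acid and the shared core kept, the loss of all three nitrogens and of the hydrogen-bond donors counted in that group does not move the read-out beyond the scatter at this place. No measurement accompanies this step that could explain the result.

From the compounds shown here alone, whether a phenyl ring or a primary amine on a shorter chain at this carbon would shift the number beyond the scatter remains open. The compounds shown also leave open whether the defined stereocentre of sec-butyl matters, as no pair here tests it.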